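Methoxy for Fluoro on the Amide Aryl Ring

A few compounds are considered here, and "the series" means these few. Any claim that something is new, unique, unknown or untested is made for them only; others in the source may bear on it.

Compound 1 `CN(C)C(=O)c1cc2cnc(Nc3ccc(NC(=O)C4(C(=O)Nc5cccc(F)c5)CC4)cc3)nc2n1C1CCCC1` stands highest of the three compounds measured in a functional assay on A549 cells (Homo sapiens) for inhibition, read by CCK-8 assay, with a stated time of 72 h, tested at 10 uM (on this read-out higher numbers stand for more inhibition of growth at the one concentration tested and lower numbers for less inhibition of growth), where compound 1 gives 91.8%. Compound 3 `CN(C)C(=O)c1cc2cnc(Nc3ccc(NC(=O)C4(C(=O)Nc5cccc(Cl)c5)CC4)cc3)nc2n1C1CCCC1` is nearest: compound 3 gives 90.7%, and the step of a number 1.1 percentage points lower from compound 1 to compound 3 (within the scatter) lies within the scatter. Compound 2 `COc1ccc(NC(=O)C2(C(=O)Nc3ccc(Nc4ncc5cc(C(=O)N(C)C)n(C6CCCC6)c5n4)cc3)CC2)cc1` is furthest, and compound 2 gives 78.5%.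

Compound 4 `COc1cccc(NC(=O)C2(C(=O)Nc3ccc(Nc4ncc5cc(C(=O)N(C)C)n(C6CCCC6)c5n4)cc3)CC2)c1` differs from compound 1 by methoxy in place of fluoro on an aromatic carbon. For the measured compounds named here, two measured steps bear on this change. The exchange a number 13.3 percentage points lower from compound 1 to compound 2 (beyond the scatter) put a methoxy on that ring, though as 4-methoxyphenyl in place of 3-fluorophenyl, and cost a modest amount; the reverse, a number 12.2 percentage points higher from compound 2 to compound 3 (beyond the scatter), recovered about as much. Neither step places the methoxy as compound 4 does, so their bearing is indirect, and the change itself is small in what leaves and what enters. A downward step smaller than those two is therefore expected for compound 4, namely a number 5.8 percentage points lower from compound 1 to compound 4 (within the scatter). Compound 4 is estimated at 86% in this assay, between 74% and 94%.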

Compound 4, percent growth inhibition at one concentration: 96%
Estimate against measurement, compound 4: 10 percentage points below, outside the stated range (above it).
By their numbers in this assay, from the lowest: compound 2; then compounds 3, 1 and 4 (each within the scatter of the next).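

In this assay, 3-methoxyphenyl in place of 4-methoxyphenyl gives a number 17.5 percentage points higher from compound 2 to compound 4 (beyond the scatter), so the lower number seen earlier with a methoxy on this ring goes with the 4-methoxyphenyl group and not with methoxy as such. On the carbon that carries the halogen, methoxy in place of fluoro gives a number 4.2 percentage points higher from compound 1 to compound 4 (within the scatter), and methoxy in place of chloro gives a number 5.3 percentage points higher from compound 3 to compound 4 (within the scatter). Fluoro, chloro and methoxy at this place therefore cannot be told apart in this assay, even though methoxy, unlike fluoro, counts a hydrogen-bond acceptor.

Nothing measured here gives a reason for the difference between the two methoxy placements. On these data alone, whether an amine, a carboxylic acid or a longer chain such as butoxy at this place would hold the number in this assay remains open.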